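Propyl to tert-Butyl Ester Change and Adenosine Receptor Binding

The compounds below may be only part of what the source reports. "The series", "measured", "known", "first", "only" and "open" are said of these compounds alone.

Measured compounds:
compound 1, `CCCOC(=O)C1=C(C)NC(=O)NC1c1ccoc1`: 50%
compound 2, `CC1=C(C(=O)OC(C)(C)C)C(c2ccoc2)NC(=O)N1`: 11%
compound 3, `CCCOC(=O)C1=C(C)NC(=S)NC1c1cccs1`: 7%

Of the compounds shown here, three have been tested in an assay on membranes from CHO cells for displacement of a labelled ligand from adenosine receptor A1 (Homo sapiens), read by scintillation counting, with a stated time of 60 min, tested at 1 uM; on this read-out lower numbers stand for less inhibition and higher numbers for more inhibition at the one concentration tested (going by the name of the read-out). Compound 1 gives 50%. Compound 2 carries the change tert-butyl in place of propyl on an oxygen next to a carbonyl group and gives 11%, so that the step of a number 39 percentage points lower from compound 1 to compound 2 (beyond the scatter) is a large loss. Compound 3 gives 7%; it stands lowest of the three, within the scatter of compound 2 and beyond the scatter of compound 1. Compound 3 and compound 1 differ in more than one place, and the difference between the two cores is not broken down here.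

Compound 4, `CC1=C(C(=O)OC(C)(C)C)C(c2cccs2)NC(=S)N1`, has not been measured. It is related to compound 3 by the change (tert-butyl in place of propyl on an oxygen next to a carbonyl group), which is the same change that leads from compound 1 to compound 2, at the same place in both cases. That change cost a large step in the first pair. For compound 4 a drop of that size is not possible because compound 3 gives 7%, which already lies near the bottom of the scale. The expected step of a number 2 percentage points lower from compound 3 to compound 4 (within the scatter) is therefore small. Compound 4 is estimated at 5%, expected to lie between 0% and 15%.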

Compound 4, a percentage reported as inhibition, at one concentration (the size of the read-out at that concentration, not a potency): 22%
Compound 4: middle estimate off by 17 percentage points, on the low side, outside the stated range (above it).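

In this assay, putting tert-butyl in place of propyl on an oxygen next to a carbonyl group gives a number 15 percentage points higher from compound 3 to compound 4 (beyond the scatter), whereas the same change on the core of compound 1 gave a number 39 percentage points lower from compound 1 to compound 2 (beyond the scatter). The two steps run in opposite directions and do not agree: the same change on two cores in this assay, a number 39 percentage points lower (beyond the scatter) from compound 1 to compound 2 and a number 15 percentage points higher (beyond the scatter) from compound 3 to compound 4, 54 percentage points apart, beyond the scatter of two such steps This shows that, among the compounds here, the result of this change on one core does not carry over to the other, but it does not show why the outcome reverses, and two pairs give no rule for any further core in the series.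

The compounds shown leave open how other groups on that oxygen would read on either core, such as methyl, isopropyl or a longer chain, or how a carboxylic acid would read in place of the ester. Also open is which of the several differences between the two cores goes with the reversal, since the compounds shown change those differences only together.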